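Working notes: from compound 3 to compound 4

A few compounds are considered here, and "the series" means these few. Any claim that something is new, unique, unknown or untested is made for them only; others in the source may bear on it.

Measured compounds:
compound 1, `COc1cc2c(Oc3ccc(NC(=O)c4cc(-c5ccccc5)nc5ccccc45)cc3F)ccnc2cc1OCCCN1CCCCC1`: 1490 nM
compound 3, `COc1cc2c(Oc3ccc(NC(=O)c4cc(-c5ccccc5)nc5ccc(F)cc45)cc3F)ccnc2cc1OCCCN1CCCCC1`: 690 nM
compound 2, `COc1cccc(-c2cc(C(=O)Nc3ccc(Oc4ccnc5cc(OCCCN6CCCCC6)c(OC)cc45)c(F)c3)c3ccccc3n2)c1`: "not determined" (no result reported)

Two compounds of the series have numbers in a functional assay on U-87MG ATCC cells (Homo sapiens) for cytotoxicity, read by MTT assay, with a stated time of 72 h; on this read-out higher numbers stand for weaker inhibition and lower numbers for stronger inhibition. Compound 1 gives 1490 nM and compound 3 gives 690 nM. Compound 2 carries the 3-methoxyphenyl that also appears in compound 4, but in this assay compound 2 gives "not determined" (no result reported). Among the compounds with values here, compound 3 therefore holds the lowest of the two numbers; the one measured step, a 2.2-fold lower number from compound 1 to compound 3 (0.33 log units; beyond the scatter), is modest but beyond the scatter.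

Compound 4 `COc1cccc(-c2cc(C(=O)Nc3ccc(Oc4ccnc5cc(OCCCN6CCCCC6)c(OC)cc45)c(F)c3)c3cc(F)ccc3n2)c1` differs from compound 3 by methoxy in place of hydrogen on an aromatic carbon. Within the data shown here, no measured step bears on this change: the only pair that would, compound 1 against compound 2, has no number for compound 2, and the step from compound 1 to compound 3 concerns a fluoro on a different ring. With nothing to indicate a direction, the expectation for compound 4 is a step of a 1.0-fold higher number from compound 3 to compound 4 (0.01 log units; within the scatter), i.e. none beyond the scatter. Compound 4 is thus estimated at 700 nM in this assay, with a range from 250 nM to 2000 nM.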

Compound 4, half-maximal inhibitory concentration: 1610 nM
The estimate for compound 4 lay 2.3-fold (0.36 log units) below the measured number, within the range that was stated.
By their numbers in this assay, from the lowest: compound 3; then compounds 1 and 4 (each within the scatter of the next).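

In this assay, within the data shown here, the change from phenyl to 3-methoxyphenyl gives a 2.3-fold higher number from compound 3 to compound 4 (0.37 log units; beyond the scatter) and so supplies the first readable number for a substituent on this ring, on an aromatic carbon meta to a large group. Among these compounds, the position is therefore not indifferent to substitution, and methoxy here moves the number in the direction of weaker inhibition, whereas the one earlier step, a 2.2-fold lower number from compound 1 to compound 3 (0.33 log units; beyond the scatter) on a different ring, moved it towards stronger inhibition. No measured data on these compounds account for the step in this assay.

On these data alone, the same methoxy change without the fluoro, from compound 1 to compound 2, cannot be read, so it remains open whether the step depends on the fluoro of compound 3 and compound 4. Also open, as far as these compounds go, is whether the step is specific to methoxy or would be shared by another group on the same carbon, such as a hydroxy group, an amine or a carboxylic acid.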